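The compounds below may be only part of what the source reports. "The series", "measured", "known", "first", "only" and "open" are said of these compounds alone.

In a functional assay on A549 cells (Homo sapiens) for antiproliferative activity, read by MTT assay, with a stated time of 72 h (on this read-out higher numbers stand for weaker inhibition and lower numbers for stronger inhibition), compound 2 `COc1cc2nccc(Oc3ccc(NC(=O)c4ncc(-c5ccc(F)cc5)o4)cc3)c2cc1OC` gives 5590 nM, the highest number among the three compounds measured. Compound 3 `COc1cc2nccc(Oc3ccc(NC(=O)c4nnc(-c5ccc(F)cc5)o4)cc3)c2cc1OC` gives 5140 nM, and the step of a 1.1-fold lower number from compound 2 to compound 3 (0.04 log units; within the scatter) stays within the scatter. Compound 1 `COc1cc2c(Oc3ccc(NC(=O)C4(c5nnc(-c6ccc(F)cc6)o5)CC4)cc3F)ccnc2cc1OCCCN1CCCC1` gives 150 nM; it differs from compound 2 at more than one place, so only the two values themselves can be set side by side. Compound 4 `COc1cc2c(Oc3ccc(NC(=O)c4ncc(-c5ccc(F)cc5)o4)cc3)ccnc2cc1OCCCN1CCC(C)CC1` differs from compound 2 by 2-(4-methylpiperidin-1-yl)ethyl in place of hydrogen on a saturated chain carbon bound to an oxygen on an aromatic ring. Among the compounds with values here, no measured step isolates this change, and the step between compound 2 and compound 3 concerns another part of the molecule. Guided by the values of compound 1 and compound 2, compound 4 is expected to show a step toward a lower number, a 6.2-fold lower number from compound 2 to compound 4 (0.79 log units; beyond the scatter). Compound 4 is estimated at 900 nM, with a range from 250 nM to 3200 nM.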

Compound 4, half-maximal inhibitory concentration: 240 nM
Compound 4: the middle estimate sits 3.8-fold (0.57 log units) above what was measured, and the stated range ends above it.
By their numbers in this assay, from the lowest: compounds 1 and 4 (each within the scatter of the next); then compounds 3 and 2 (each within the scatter of the next).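

In this assay, within the data shown here, 2-(4-methylpiperidin-1-yl)ethyl in place of hydrogen at this position gives a 23-fold lower number from compound 2 to compound 4 (1.37 log units; beyond the scatter), the first single-place step here that lies beyond the scatter. This position therefore accepts the longer chain with its six-membered non-aromatic ring, and the number falls sharply. Nothing at hand explains the size of this step. The compounds shown leave open how much of the step comes from the chain alone, as a plain propoxy would show. They also leave open whether a morpholine at the chain end would give a similar step.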